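This account rests on a few compounds, and the source may have more. Where it says the series, first, only, none or still open, it means among the compounds named here.

Compound 1 `CCCCc1ccc(-c2c(C)[nH]c(=O)n2C)cc1` carries a butyl chain on its aromatic ring. Among the compounds with values here, in a functional assay on brain (Rattus norvegicus, strain Wistar) for inhibition (a higher number here means a weaker inhibitor, a lower number a stronger inhibitor), compound 1 gives 10700 nM, the lowest number of the three measured so far, though compound 2 sits within the scatter of it. Compound 2 `CCCCc1ccc(-c2c(CC)[nH]c(=O)n2C)cc1` gives 13900 nM, a step of a 1.3-fold higher number from compound 1 to compound 2 (0.11 log units; within the scatter). Compound 3 `CCCCc1ccc(-c2c(C)[nH]c(=O)n2C2CCCCC2)cc1` gives 27100 nM, a step of a 2.5-fold higher number from compound 1 to compound 3 (0.40 log units; beyond the scatter). Compound 4 `CCCc1ccc(-c2c(C)[nH]c(=O)n2C)cc1` differs from compound 1 by hydrogen in place of methyl on a saturated chain carbon, three bonds along the chain from an aromatic carbon. Neither measured step touches this chain: one adds to a saturated chain carbon bound to an aromatic carbon, the other swaps the group on the aromatic nitrogen. Both were small to modest, so only a small step, if any, is expected here, with no clear direction. Compound 4 is therefore estimated at 13000 nM, between 6000 nM and 30000 nM, an expected step of a 1.2-fold higher number from compound 1 to compound 4 (0.08 log units; within the scatter).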

Compound 4, half-maximal inhibitory concentration: 21500 nM
Compound 4: middle estimate off by 1.7-fold (0.22 log units), on the low side, and the stated range covers the measured number.
By their numbers in this assay, from the lowest: compounds 1, 2, 4 and 3 (each within the scatter of the next, the first and the last beyond it).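

Butyl to propyl is the first change shown three bonds along the chain from an aromatic carbon, and in this assay it gives a 2.0-fold higher number from compound 1 to compound 4 (0.30 log units; within the scatter). Losing this methyl therefore leaves compound 4 not clearly separated from compound 1. Nothing available explains this result. As far as these compounds go, whether a longer chain such as pentyl, or a shorter one such as ethyl, would give a step beyond the scatter remains open. So does what an amine or a carboxylic acid would do at this place.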